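This account rests on a few compounds, and the source may have more. Where it says the series, first, only, none or still open, it means among the compounds named here.

Working notes on the series. In a functional assay on HL-60 cells (Homo sapiens) for cytotoxicity, read by MTT assay, with a stated time of 72 h (on this read-out lower numbers stand for stronger inhibition and higher numbers for weaker inhibition), compound 1 (`Cc1ccc(S(=O)(=O)c2nc3ccccc3nc2N2CCc3ccccc3C2)cc1`) gives 3610 nM, compound 2 (`COc1ccc(S(=O)(=O)c2nc3ccccc3nc2N2CCc3ccccc3C2)cc1`) gives 3690 nM and compound 3 (`O=S(=O)(c1ccc(Br)cc1)c1nc2ccccc2nc1N1CCc2ccccc2C1`) gives 2610 nM. These three values lie within the scatter of one another, so compound 2 holds no distinct place among them. Compound 4 (`COc1ccc(S(=O)(=O)c2nc3ccccc3nc2N2CCCC(O)C2)cc1`) carries 3-hydroxypiperidin-1-yl in place of 1,2,3,4-tetrahydroisoquinolin-2-yl on an aromatic carbon. The measured steps are a 1.0-fold higher number from compound 1 to compound 2 (0.01 log units; within the scatter), a 1.4-fold lower number from compound 1 to compound 3 (0.14 log units; within the scatter) and a 1.4-fold lower number from compound 2 to compound 3 (0.15 log units; within the scatter). All three exchange methyl, methoxy or bromo, and none touches the place of this change, so they fix neither its size nor its direction. The group that enters lacks the aromatic ring of the group that leaves, and on that judgement alone a moderately higher number is expected in this assay, with wide uncertainty. The expected change is a 2.2-fold higher number from compound 2 to compound 4 (0.34 log units; beyond the scatter). For compound 4 the estimate is 8000 nM, with an expected range of 2500 nM to 25000 nM.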

Compound 4, half-maximal inhibitory concentration: 3050 nM
For compound 4 the middle estimate is 2.6-fold (0.42 log units) above the measured one; measured number inside the range.
By their numbers in this assay, from the lowest: compounds 3, 4, 1 and 2 (each within the scatter of the next).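

At this place, a 1.2-fold lower number from compound 2 to compound 4 (0.08 log units; within the scatter) in this assay when 3-hydroxypiperidin-1-yl stands in place of 1,2,3,4-tetrahydroisoquinolin-2-yl. In this pair, therefore, the six-membered aromatic ring of the leaving group can be lost without a step beyond the scatter. Nothing available bears on why the two groups read alike.

Going by these compounds, whether the hydroxyl contributes remains open, and a plain piperidin-1-yl or a carboxylic acid on the same ring would test this. Also open, on these data alone, is whether the exchange reads the same with methyl or bromo in place of methoxy.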